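Notes on chloro addition to compound 3

This account rests on a few compounds, and the source may have more. Where it says the series, first, only, none or still open, it means among the compounds named here.

Measured in a functional assay on HCT-116 cells (Homo sapiens) for cytotoxicity, read by MTT assay, with a stated time of 72 h; a higher number here means a weaker inhibitor, a lower number a stronger inhibitor
- compound 1 `Nc1ccccc1NC(=O)c1ccc(Cn2cc(-c3ccc(NC(=O)NCc4cccnc4)cc3)nn2)cc1` gives > 100000 nM (a limit of the assay, not a number)
- compound 2 `Nc1ccccc1NC(=O)c1ccc(NC(=S)NCc2cccc(Cl)c2)cc1` gives 5900 nM
- compound 3 `Nc1ccccc1NC(=O)c1ccc(NC(=O)NCc2cccnc2)cc1` gives 9400 nM

Compound 3 at 9400 nM lies within the scatter of compound 2 at 5900 nM, so these two are not ranked. Compound 4 `Nc1ccccc1NC(=O)c1ccc(NC(=O)NCc2ccc(Cl)nc2)cc1` is compound 3 with chloro in place of hydrogen on an aromatic carbon, next to the ring nitrogen (chloro in place of hydrogen on an aromatic carbon). For the measured compounds named here, no measured pair differs in one place only, so no direct guide exists. Compound 2 at 5900 nM also carries a chloro group, alongside other differences. The expected 1.3-fold lower number from compound 3 to compound 4 (0.13 log units; within the scatter) is small, slightly towards a lower number and not beyond the scatter. For compound 4 the estimated value is 7000 nM, with an expected range of 2500 nM to 20000 nM.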

Compound 4, half-maximal inhibitory concentration: 5200 nM
Estimate against measurement, compound 4: 1.3-fold (0.13 log units) above; low and high end bracket the measured number.
By their numbers in this assay, from the lowest: compounds 4, 2 and 3 (each within the scatter of the next). At a limit, above all of these: compound 1.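

Chloro in place of hydrogen on this aromatic carbon, next to the ring nitrogen, gives a 1.8-fold lower number from compound 3 to compound 4 (0.26 log units; within the scatter) in this assay. This is the first change in the series that can be read in one place, and it shows that 6-chloropyridin-3-yl holds the number within the scatter of pyridin-3-yl. (No measurement shown gives a cause for this step).

Going by these compounds, whether an amine or a methoxy group on this carbon would go beyond the scatter remains open. So does the effect of chloro on the other carbons of this ring.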